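The source may report more compounds than this note shows. Statements on the series, on what has been measured and on what is new or still open speak of the compounds shown alone.

In a functional assay on HUVEC cells (Homo sapiens) for inhibition, with stated times of 2 h and 72 h (on this read-out higher numbers stand for weaker inhibition and lower numbers for stronger inhibition), compound 1 `COc1cc2nccc(Oc3ccc4c(NC(=O)c5cccc(C(F)(F)F)c5)nn(C)c4c3)c2cc1OC` has no exact number. Compound 1 gives > 1000 nM, which is a limit of the assay. Compound 2 `COc1cc2nccc(Oc3ccc4c(NC(=O)c5cc(C(F)(F)F)cc(C(F)(F)F)c5)nn(C)c4c3)c2cc1OC` gives > 1000 nM, also a limit. Compound 3 `COc1cc2nccc(Oc3ccc4c(NC(=O)c5cc(Cl)ccn5)nn(C)c4c3)c2cc1OC` gives > 1000 nM, again a limit. All three thus sit at one boundary: the limit of > 1000 nM in this assay, at which 3 of the 3 values shown sit.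

Compound 4 `COc1cccc(Nc2nn(C)c3cc(Oc4ccnc5cc(OC)c(OC)cc45)ccc23)c1` carries 3-methoxyphenyl in place of (3-(trifluoromethyl)phenyl)carbonyl on a nitrogen on an aromatic ring. Among the compounds with values here, two measured steps bear on this group, and neither has a readable size: a step that the two limits leave unreadable from compound 1 to compound 2 and a step that the two limits leave unreadable from compound 1 to compound 3. They therefore support no expected shift beyond the scatter in this assay, in either direction. The expected step is a step that the limit leaves unreadable from compound 1 to compound 4. Compound 4 is estimated at 2500 nM, within an expected range of 600 nM to 10000 nM.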

Compound 4, half-maximal inhibitory concentration: > 1000 nM
Compound 4 gave a limit, no number; the forecaster's own chance of this, stated with the estimate: 80%; the middle value does not contradict the limit.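

Compound 4 gives > 1000 nM, which is a limit of the assay, so the steps from compound 1 and from compound 3 to compound 4 cannot be read. The compounds shown leave open how the changes affect inhibition, as all share one boundary: the limit of > 1000 nM in this assay, at which 4 of the 4 values shown sit.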